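This account rests on a few compounds, and the source may have more. Where it says the series, first, only, none or still open, it means among the compounds named here.

Measured so far in a functional assay on B16-F10 cells (Mus musculus) for inhibition, read by MTT assay, with a stated time of 72 h; a higher number here means a weaker inhibitor, a lower number a stronger inhibitor:
Compound 1 `CC(C)c1ccc(-c2nc(SCc3cn(CC(=O)NC(=O)Nc4ccccn4)nn3)nc(Nc3cccc(Cl)c3)c2C#N)cc1` gives 1130 nM.
Compound 2 `CC(C)c1ccc(-c2nc(SCc3cn(CC(=O)NC(=O)Nc4ccccn4)nn3)nc(Nc3cccc([N+](=O)[O-])c3)c2C#N)cc1` gives 26400 nM.
Compound 3 `CC(C)c1ccc(-c2nc(SCc3cn(CC(=O)NC(=O)Nc4ccccn4)nn3)nc(Nc3ccccc3F)c2C#N)cc1` gives 8380 nM.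

Compound 3 stands second highest of the three numbers: nearest is compound 2 (a 3.2-fold lower number from compound 2 to compound 3 (0.50 log units; beyond the scatter)), furthest is compound 1 (a 7.4-fold higher number from compound 1 to compound 3 (0.87 log units; beyond the scatter)). Compound 4 `COc1ccc(Nc2nc(SCc3cn(CC(=O)NC(=O)Nc4ccccn4)nn3)nc(-c3ccc(C(C)C)cc3)c2C#N)cc1` differs from compound 3 by 4-methoxyphenyl in place of 2-fluorophenyl on a nitrogen on an aromatic ring. Among the compounds with values here, no measured step involves a 4-methoxyphenyl at this nitrogen; the only steps touching this position exchange 2-fluorophenyl against 3-chlorophenyl or 3-nitrophenyl, and both went beyond the scatter, so the position is sensitive. The direction for compound 4 cannot be read from the data, so the expected step of a 1.7-fold lower number from compound 3 to compound 4 (0.22 log units; within the scatter) is set near no change, with a wide range. Compound 4 is estimated at 5000 nM in this assay, expected between 1200 nM and 25000 nM.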

Compound 4, half-maximal inhibitory concentration: 360 nM
Compound 4: the middle estimate sits 14-fold (1.14 log units) above what was measured; the whole stated range lies above it.
By their numbers in this assay, from the lowest: compound 4; then compound 1; then compound 3; then compound 2.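

In this assay, 4-methoxyphenyl is the strongest of the four at this nitrogen, with a 23-fold lower number from compound 3 to compound 4 (1.37 log units; beyond the scatter), a 73-fold lower number from compound 2 to compound 4 (1.87 log units; beyond the scatter) and a 3.1-fold lower number from compound 1 to compound 4 (0.50 log units; beyond the scatter). The earlier compounds shown here showed only losses from 3-chlorophenyl; this change shows that the number at this position can also fall below that of compound 1. Nothing measured here explains the gain.

The compounds shown change the substituent and its ring position together, leaving open whether the gain follows the methoxy group or its placement. 3-Methoxyphenyl, 4-chlorophenyl and 4-aminophenyl would separate these readings.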